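Pentan-3-yl in place of isobutyl: working notes on exposure

A few compounds are considered here, and "the series" means these few. Any claim that something is new, unique, unknown or untested is made for them only; others in the source may bear on it.

- compound 1 `Cc1ccc([C@H](C(=O)N(C)C)N2C(=O)[C@@H](C3Cc4ccccc4C3)NC(=O)[C@H]2CC(C)C)cn1` gives 454 ng.h/mL
- compound 2 `CC[C@H](C)[C@@H]1C(=O)N[C@H](C2Cc3ccccc3C2)C(=O)N1[C@@H](C(=O)N(C)C)c1ccc(C)[n+]([O-])c1` gives 73 ng.h/mL
- compound 3 `CC[C@H](C)[C@@H]1C(=O)N[C@H](C2Cc3ccccc3C2)C(=O)N1[C@@H](C(=O)N(C)C)c1cnc(C)cc1C` gives 140 ng.h/mL
- compound 4 `CCC(CC)[C@@H]1C(=O)N[C@H](C2Cc3ccccc3C2)C(=O)N1[C@@H](C(=O)N(C)C)c1ccc(C)nc1` is not yet measured

All values come from an ADME assay on the whole organism (plasma) for pharmacokinetics, with Canis familiaris (Canis lupus familiaris) as the target, at a dose of 0.6 mg/kg by the oral route; on this read-out lower numbers stand for lower exposure and higher numbers for higher exposure at the dose given. Compound 1 has the highest of the three numbers, and both compound 2 and compound 3 lie lower by more than the scatter.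

The next step goes from compound 1 to compound 4, with pentan-3-yl in place of isobutyl on a saturated ring carbon. The rest of the structure stays as in compound 1.

For the measured compounds named here, only one single-place step has been measured: a 1.9-fold higher number from compound 2 to compound 3 (0.28 log units; within the scatter). That step concerns the aromatic group on the saturated chain carbon, not the ring carbon that changes here, so it bears on this change only indirectly. Going by the values given here, no measured step replaces the group on that ring carbon, and the size of the coming step in this assay therefore remains open. No step beyond the scatter is expected, and the range is kept wide to reflect how little the data constrain it. The expected change is a 1.5-fold lower number from compound 1 to compound 4 (0.18 log units; within the scatter).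

For compound 4 the estimated value is 300 ng.h/mL, with an expected range of 100 ng.h/mL to 800 ng.h/mL.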

Compound 4, area under the concentration-time curve: 255 ng.h/mL
The estimate for compound 4 lay 1.2-fold (0.07 log units) above the measured number; low and high end bracket the measured number.
By their numbers in this assay, from the lowest: compounds 2, 3, 4 and 1 (each within the scatter of the next, the first and the last beyond it).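

In this assay, for the compounds shown here, the saturated ring carbon next to the ring nitrogen now has a measured replacement of its own: pentan-3-yl in place of isobutyl gives a 1.8-fold lower number from compound 1 to compound 4 (0.25 log units; within the scatter) and is the first single-place step at this position. The earlier step concerned only the aromatic group on the saturated chain carbon, whereas this one shows that, with the rest of the core of compound 1 unchanged, going from isobutyl to pentan-3-yl leaves the number within the usual scatter. Going by these compounds alone, as one pair, it sets no trend for this position and describes only this exchange of two open, all-carbon groups. No measurement bears on why the step has this size.

Open, going by these compounds, is how far this position tolerates change beyond these two groups, for instance with a cyclohexyl ring, a longer chain such as n-hexyl, or a chain carrying an amine or a carboxylic acid. Also open, on these data alone, is whether pentan-3-yl would give a step of similar size on the core of compound 3, with its different aromatic group.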